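Chain-to-ring exchange at the terminal amine of compound 3

The source may report more compounds than this note shows. Statements on the series, on what has been measured and on what is new or still open speak of the compounds shown alone.

Compound 3 `NCCNc1cc2c(cc1F)c(=O)c(C(=O)O)cn2Cc1ccc(-c2ccccc2)cc1` gives 72800 nM in an assay on isolated protein for inhibition of DNA topoisomerase 1 (Homo sapiens), with a stated time of 15 min (a higher number here means a weaker inhibitor, a lower number a stronger inhibitor), and stands as the higher of the two numbers in hand. Compound 1 `N[C@@H]1CCN(c2cc3c(cc2F)c(=O)c(C(=O)O)cn3Cc2ccc(-c3ccccc3)cc2)C1` gives 63600 nM in this assay; the step of a 1.1-fold higher number from compound 1 to compound 3 (0.06 log units; within the scatter) lies within the scatter. Compound 2 `CNCCNc1cc2c(cc1F)c(=O)c(C(=O)O)cn2Cc1ccc(-c2ccccc2)cc1` reaches only a limit in this assay, > 200000 nM. Compound 4 `O=C(O)c1cn(Cc2ccc(-c3ccccc3)cc2)c2cc(NC[C@H]3CCNC3)c(F)cc2c1=O` differs from compound 3 by pyrrolidin-3-yl in place of aminomethyl on a saturated chain carbon bound to a nitrogen on an aromatic ring. Within the data shown here, two measured steps bear on this. The ring-for-chain exchange a 1.1-fold higher number from compound 1 to compound 3 (0.06 log units; within the scatter) produced nothing beyond the scatter, whereas removing a methyl from the amine nitrogen gave an at least 2.7-fold lower number from compound 2 to compound 3 (0.43 log units; beyond the scatter), so the alkylated amine sat weaker. Compound 4 carries its amine nitrogen inside a pyrrolidin-3-yl ring, and a modest rise in this assay is therefore expected, a 1.5-fold higher number from compound 3 to compound 4 (0.18 log units; within the scatter). Compound 4 is estimated at 110000 nM, with a range from 50000 nM to 250000 nM.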

Compound 4, half-maximal inhibitory concentration: 100000 nM
For compound 4 the middle estimate is 1.1-fold (0.04 log units) above the measured one; low and high end bracket the measured number.
By their numbers in this assay, from the lowest: compounds 1, 3 and 4 (each within the scatter of the next). At a limit, above all of these: compound 2.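

Moving the amine nitrogen into a pyrrolidin-3-yl ring on the saturated chain carbon leaves the number in this assay within the scatter (a 1.4-fold higher number from compound 3 to compound 4 (0.14 log units; within the scatter)). Against the 3-aminopyrrolidin-1-yl group of compound 1, the ((pyrrolidin-3-yl)methyl)amino group likewise stays within the scatter (a 1.6-fold higher number from compound 1 to compound 4 (0.20 log units; within the scatter)). Compound 2 holds a limit, so its step gives only a floor (an at least 2.0-fold lower number from compound 2 to compound 4 (0.30 log units; that floor lies within the scatter)), and that floor rests on a single value: the limit of > 200000 nM in this assay, at which 1 of the 4 values shown sits.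

Still open, from the compounds shown here alone, is whether a hydroxyl or an amide in place of the terminal amine, or a longer chain, would move the number beyond the scatter. Going by these compounds, the opposite stereocentre of the pyrrolidin-3-yl ring also remains open.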